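The source may hold more compounds than are shown below. What is called first, only, known or untested is meant among the compounds shown, and "the series" means these compounds.

Going by the values given here, compound 3 `COc1cc2c(cc1C(C)NCc1ccccc1)CCC(C)(C)O2` is one of three compounds measured in an assay on cell membranes for displacement of a labelled ligand from Sigma non-opioid intracellular receptor 1 (Cavia porcellus), read by scintillation counting (a higher number here means a weaker inhibitor, a lower number a stronger inhibitor), where compound 3 gives 119 nM. Compound 1 `COc1ccc(CNC(C)c2cc3c(cc2OC)OC(C)(C)C=C3)cc1` gives 165 nM in this assay, and compound 2 `CCCCNC(C)c1cc2c(cc1OC)OC(C)(C)C=C2` gives 22 nM. Compound 3 therefore stands second highest of the three: its number sits close to that of compound 1, within the usual scatter, while compound 2 is clearly lower.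

Compound 4 `COc1cc2c(cc1C(C)NCCCCc1ccccc1)CCC(C)(C)O2` differs from compound 3 in one place: 3-phenylpropyl in place of phenyl on a saturated chain carbon bound to an amine nitrogen. Among the compounds with values here, the only measured step that bears on this is the one in which a longer, open chain took the place of an aromatic ring on the same kind of carbon, a 7.5-fold lower number from compound 1 to compound 2 (0.88 log units; beyond the scatter), a modest but clear gain. The change to compound 4 likewise lengthens the group on that carbon into a chain, so a step of similar size toward a lower number is expected, a 4.8-fold lower number from compound 3 to compound 4 (0.68 log units; beyond the scatter). For compound 4 in this assay the estimate is 25 nM, with a likely range from 8 nM to 80 nM.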

Compound 4, inhibition constant: 115 nM
Estimate against measurement, compound 4: 4.6-fold (0.66 log units) below; the measured number lies above the stated range.
By their numbers in this assay, from the lowest: compound 2; then compounds 4, 3 and 1 (each within the scatter of the next).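

In this assay, making the group longer at this place, on a saturated chain carbon bound to an amine nitrogen, leaves the number where it was (a 1.0-fold lower number from compound 3 to compound 4 (0.01 log units; within the scatter)). Added chain length alone therefore does not lower the number, at least on the core of compound 3. The earlier drop (a 7.5-fold lower number from compound 1 to compound 2 (0.88 log units; beyond the scatter)) came with propyl, which has no aromatic ring, whereas phenyl and 3-phenylpropyl both carry one, and no measurement shown explains the difference between these two steps.

On these data alone, it remains open whether propyl in place of phenyl on the core of compound 3 would repeat the drop seen on the core of compound 2. Also open, as far as these compounds go, is how a cyclohexyl group, a saturated ring, would compare with phenyl at this place.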